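The source may report more compounds than this note shows. Statements on the series, on what has been measured and on what is new or still open speak of the compounds shown alone.

Of the compounds shown here, three built on one shared core have been measured in an assay on isolated protein for inhibition of MAP kinase-interacting serine/threonine-protein kinase 2 (Homo sapiens), read by HTRF, in the presence of a further agent that is not named here; on this read-out higher numbers stand for weaker inhibition and lower numbers for stronger inhibition. Compound 1 `O=C(c1cccc(C#Cc2ccccc2Nc2ncnc3ccc(Cl)nc23)c1)N1CCOCC1` reaches only a limit, > 10000 nM. Compound 2 `CCCNC(=O)c1cccc(C#Cc2ccccc2Nc2ncnc3ccc(Cl)nc23)c1` gives 3900 nM. Compound 3 `O=C(c1cccc(C#Cc2ccccc2Nc2ncnc3ccc(Cl)nc23)c1)N1CCNCC1` gives 5000 nM. The numbers of compound 2 and compound 3 lie within the scatter of each other, the step being a 1.3-fold higher number from compound 2 to compound 3 (0.11 log units; within the scatter). From compound 1 the steps are an at least 2.5-fold lower number from compound 1 to compound 2 (0.40 log units; beyond the scatter) and an at least 2.0-fold lower number from compound 1 to compound 3 (0.30 log units; that floor lies within the scatter), and both rest on (the limit of > 10000 nM in this assay, at which 1 of the 3 values shown sits), so their true size is not known.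

Compound 4 `COC(=O)c1cccc(C#Cc2ccccc2Nc2ncnc3ccc(Cl)nc23)c1` has not yet been measured. It differs from compound 3 in one place: methoxy in place of piperazin-1-yl on a carbonyl carbon. All three measured steps concern the same carbonyl carbon, and none of them shows a clear movement: two start from a limit, and the third lies within the scatter. Nothing measured here shows an ester at that position, so the expectation rests on the small spread among the amides. The estimated change is therefore modest, no change at the digits printed from compound 3 to compound 4 (within the scatter), with no direction that can be trusted beyond the scatter. Compound 4 is expected to give about 5000 nM in this assay, with a likely range from 1500 nM to 15000 nM.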

Compound 4, half-maximal inhibitory concentration: 4200 nM
Compound 4: middle estimate off by 1.2-fold (0.08 log units), on the high side; the measured number falls inside the stated range.
By their numbers in this assay, from the lowest: compounds 2, 4 and 3 (each within the scatter of the next). At a limit, above all of these: compound 1.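

Until now every compound at this carbonyl carbon was an amide, and compound 4 shows that an ester can stand there in this assay without a change that can be told from the scatter. Methoxy is much the smaller group, with no ring and no hydrogen-bond donor, yet the comparison with the piperazin-1-yl amide gives a 1.2-fold lower number from compound 3 to compound 4 (0.08 log units; within the scatter) and the comparison with the propylamino amide gives a 1.1-fold higher number from compound 2 to compound 4 (0.03 log units; within the scatter), so neither the ring, nor that donor, nor the amide nitrogen itself is needed to hold the number at this level. Only the morpholin-4-yl amide goes against this picture, with an at least 2.3-fold lower number from compound 1 to compound 4 (0.37 log units; beyond the scatter), and that step is a floor rather than a true size: the limit of > 10000 nM in this assay, at which 1 of the 4 values shown sits.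

On these data alone, what remains open is whether any group at this carbonyl carbon can bring the number clearly below the level shared by compounds 2, 3 and 4, since all three sit within the scatter of one another. A free carboxylic acid, a primary amide or a chain longer than propylamino would probe this further, and a 4-methylpiperazin-1-yl amide would help to show how sharply the outcome differs between the morpholin-4-yl and piperazin-1-yl rings.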